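The source may report more compounds than this note shows. Statements on the series, on what has been measured and on what is new or still open speak of the compounds shown alone.

Compound 1 `CC(C)(C)Cn1cc2c(Cl)nc(NC(=O)c3ccccc3)nc2n1`: 30300 nM in an assay on CHO cells for displacement of a labelled ligand from adenosine receptor A3 (Homo sapiens), read by scintillation counting, with a stated time of 3 h; on this read-out lower numbers stand for stronger inhibition and higher numbers for weaker inhibition
Compound 2 `CC(C)(C)Cn1cc2c(Cl)nc(NC(=O)c3ccc(C(F)(F)F)cc3)nc2n1`: 6600 nM
Compound 3 `CC(C)n1cc2c(Cl)nc(NC(=O)c3ccc(F)cc3)nc2n1`: > 60000 nM, which is a limit of this assay and not a number

Compound 3 thus stands at the limit of > 60000 nM in this assay, at which 1 of the 3 values shown sits, the only one of the three without a measured number. Compound 4 `CC(C)(C)Cn1cc2c(Cl)nc(NC(=O)c3ccc(F)cc3)nc2n1` keeps everything of compound 3 except the chain on the ring nitrogen: neopentyl in place of isopropyl on an aromatic nitrogen. Within the data shown here, the single measured step, a 4.6-fold lower number from compound 1 to compound 2 (0.66 log units; beyond the scatter), alters the amide part and not this chain, so no measured step bears directly on the change. What the data do show is that compound 1 and compound 2, both carrying neopentyl, return numbers in this assay, whereas compound 3 with isopropyl does not. Compound 4 is therefore expected to return a number, estimated at 20000 nM with a range from 5000 nM to 60000 nM. The expected step is an at least 3.0-fold lower number from compound 3 to compound 4 (0.47 log units; beyond the scatter).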

Compound 4, inhibition constant: 5900 nM
Beside the measured number, compound 4's estimate is 3.4-fold (0.53 log units) above it; the measured number falls inside the stated range.
By their numbers in this assay, from the lowest: compounds 4 and 2 (each within the scatter of the next); then compound 1. At a limit, above all of these: compound 3.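

Neopentyl in place of isopropyl on an aromatic nitrogen now has a step of its own, with the amide part unchanged: an at least 10-fold lower number from compound 3 to compound 4 (1.00 log units; beyond the scatter). As far as these compounds go, compound 3 has a limit and not a number, so the true size of that step is unknown: the limit of > 60000 nM in this assay, at which 1 of the 4 values shown sits. Fluoro in place of hydrogen gives a 5.1-fold lower number from compound 1 to compound 4 (0.71 log units; beyond the scatter), while fluoro in place of trifluoromethyl gives a 1.1-fold lower number from compound 2 to compound 4 (0.05 log units; within the scatter), so these two groups cannot be told apart here.

From the compounds shown here alone, whether a longer chain or a cyclohexyl ring on that aromatic nitrogen would change the number remains open.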